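The compounds below may be only part of what the source reports. "The series", "measured", "known", "first", "only" and "open" are said of these compounds alone.

In a functional assay on KB 3-1 cells (Homo sapiens) for cytotoxicity, read by MTT assay, with a stated time of 68 h (a higher number here means a weaker inhibitor, a lower number a stronger inhibitor), compound 1 `Nc1cccc(-c2cccc(NC(=O)C(Cl)Cl)c2)c1` gives 26100 nM and compound 3 `CCOc1cccc(-c2cc(NC(=O)C(Cl)Cl)cc(-c3cccc(OCC)c3)c2)c1` gives 14800 nM, two values within the usual scatter of each other. Compound 2 `O=C(Nc1cccc(-c2ccsc2)c1)C(Cl)Cl` yields only a limit of the assay, > 50000 nM. Compound 1 therefore holds one of just two true numbers, with no real separation from the other. Compound 4 `O=C(Nc1cccc(-c2cccc(Cl)c2)c1)C(Cl)Cl` keeps the core of compound 1 but carries chloro in place of amino on an aromatic carbon. For the measured compounds named here, no measured pair isolates this change, so no step beyond the scatter is expected in this assay, and the estimated step of a 1.3-fold lower number from compound 1 to compound 4 (0.12 log units; within the scatter) remains small. For compound 4 the expected value is 20000 nM, with an estimated range of 8000 nM to 50000 nM.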

Compound 4, half-maximal inhibitory concentration: > 50000 nM
Compound 4: no number, only a limit; the forecaster's own chance of this, stated with the estimate: 20%; middle value at least 2.5-fold (0.39 log units) from the limit.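

In this assay compound 4 returns no number, only a limit of > 50000 nM. For the compounds shown here, this gives the first comparison in the set that differs in one place: chloro in place of amino on an aromatic carbon gives an at least 1.9-fold higher number from compound 1 to compound 4 (0.28 log units; that floor lies within the scatter), so only a floor can be read and the true size of the step stays unknown. The top of the assay's range now constrains what this position can show: the limit of > 50000 nM in this assay, at which 2 of the 4 values shown sit.

As far as these compounds go, what a hydroxyl or a carboxylic acid at this place would give remains open. From the compounds shown here alone, how far the true value of compound 4 lies from its limit is also open.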